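From 5-acetylthiophen-2-yl to 3-hydroxyphenyl: expected cytotoxicity

A few compounds are considered here, and "the series" means these few. Any claim that something is new, unique, unknown or untested is made for them only; others in the source may bear on it.

Compound 1, `CCOC(=O)CCCCCOc1cccc(CN(C(=O)c2ccc(-c3ccc4ccccc4c3)cc2)C(C)C)c1`: in an ADME assay on HEK293 cells (Homo sapiens) for cytotoxicity, read by CellTiter-Glo and resazurin assay, with a stated time of 72 h (a higher number here means that more compound is needed for the effect, a lower number that less compound is needed), compound 1 reaches only the limit > 26000 nM.
Compound 2, `CCOC(=O)CCCCCOc1cccc(CN(C(=O)c2ccc(-c3cccc(Oc4ccccc4)c3)cc2)C(C)C)c1`: in this assay compound 2 reaches only the limit > 19600 nM.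
Compound 3, `CCOC(=O)CCCCCOc1cccc(CN(C(=O)c2ccc(-c3ccc(C(C)=O)s3)cc2)C(C)C)c1`: in this assay compound 3 reaches only the limit > 26000 nM.

Compound 3 therefore stands at a limit, not at a number, and the two other values shown are limits as well, sitting at the limit of > 19600 nM in this assay, at which 1 of the 3 values shown sits, and (the limit of > 26000 nM in this assay, at which 2 of the 3 values shown sit). For the measured compounds named here, the only step between neighbours, a step that the two limits leave unreadable from compound 1 to compound 3, cannot be read because both ends rest on (the limit of > 26000 nM in this assay, at which 2 of the 3 values shown sit).

Compound 4, `CCOC(=O)CCCCCOc1cccc(CN(C(=O)c2ccc(-c3cccc(O)c3)cc2)C(C)C)c1`, differs from compound 3 by 3-hydroxyphenyl in place of 5-acetylthiophen-2-yl on an aromatic carbon. Going by the values given here, no measured step bears on this change, so nothing beyond the scatter is expected in this assay, and compound 4 is expected to end at the limit again.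

Compound 4 is estimated at 26000 nM, ranging from 13000 nM to 52000 nM.

The step of a number no higher from compound 3 to compound 4 (the limit leaves the size open) is expected to stay within the scatter.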

Compound 4, half-maximal effective concentration: > 26000 nM
Compound 4 ended at the assay's limit; the forecaster's own chance of this, stated with the estimate: 75%; the middle value lies on the limit itself.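

For the compounds shown here, compound 1, compound 2, compound 3 and compound 4 all stand at limits, so no step between them can be read in this assay. The compounds shown leave open what concentration of each one reaches the effect.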